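The source may hold more compounds than are shown below. What is called first, only, known or untested is meant among the compounds shown, and "the series" means these compounds.

Measured compounds, in a toxicity assay on HEK-293T cells (Homo sapiens) for cytotoxicity, read by MTT assay, with a stated time of 72 h; a higher number here means a weaker inhibitor, a lower number a stronger inhibitor:
Compound 1 `O=C1c2c[n+]([O-])c3ccccc3c2C(=O)c2c1c1ccccc1n2Cc1cn([C@@H]2C[C@H](O)[C@@H](CO)O2)nn1`: 820 nM
Compound 2 `CN1CCN(CCCCCCn2c3c(c4ccccc42)C(=O)c2c[n+]([O-])c4ccccc4c2C3=O)CC1`: 5800 nM

Compound 1 has the lower of the two numbers in this assay and is the stronger inhibitor of the pair, a gap beyond the usual scatter. Among the compounds with values here, the two compounds differ in more than one place, so their gap does not serve as a measured step for any single change, and the series offers no such step.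

Compound 3 `O=C1c2c[n+]([O-])c3ccccc3c2C(=O)c2c1c1ccccc1n2Cc1cn([C@@H]2O[C@H](CO)[C@@H](O)[C@H](O)[C@H]2O)nn1` keeps the core of compound 1 and changes only the group on an aromatic nitrogen of the five-membered aromatic ring with 3 nitrogen: 3,4,5-trihydroxy-6-(hydroxymethyl)oxan-2-yl in place of 4-hydroxy-5-(hydroxymethyl)oxolan-2-yl on an aromatic nitrogen. Here 3,4,5-trihydroxy-6-(hydroxymethyl)oxan-2-yl stands in place of 4-hydroxy-5-(hydroxymethyl)oxolan-2-yl.

Within the data shown here, with no measured step to lean on, only a small to moderate move towards a higher number is expected in this assay, and it may not clear the scatter. The expected step is a 1.7-fold higher number from compound 1 to compound 3 (0.23 log units; within the scatter). The estimated value for compound 3 is 1400 nM, within an expected range of 450 nM to 4500 nM.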

Compound 3, half-maximal inhibitory concentration: 940 nM
For compound 3 the middle estimate is 1.5-fold (0.17 log units) above the measured one; low and high end bracket the measured number.
By their numbers in this assay, from the lowest: compounds 1 and 3 (each within the scatter of the next); then compound 2.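

In this assay, the position on an aromatic nitrogen of the five-membered aromatic ring with 3 nitrogen now has its first measured step, a 1.1-fold higher number from compound 1 to compound 3 (0.06 log units; within the scatter), for 3,4,5-trihydroxy-6-(hydroxymethyl)oxan-2-yl in place of 4-hydroxy-5-(hydroxymethyl)oxolan-2-yl. This exchange takes a five-membered non-aromatic ring to a six-membered one, 2 hydrogen-bond donors to 4, and 3 defined stereocentres to 5, yet the two compounds cannot be told apart in this read-out. The data on hand offer no independent measurement that would account for this result.

Within the data shown here, whether an amine, a carboxylic acid or a plain hexyl chain at this same place would give a step beyond the scatter remains open, as the only step at this position joins two closely related ring-bearing groups. Among these compounds, no single-change step links compound 2 to compound 1 or compound 3, so the number of compound 2, 5800 nM, cannot be assigned to any one part of its structure.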